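The source may report more compounds than this note shows. Statements on the series, on what has been measured and on what is new or still open speak of the compounds shown alone.

Measured so far in an ADME assay on L02 cells (Homo sapiens) for cytotoxicity, read by MTT assay, with a stated time of 48 h; a higher number here means a weaker inhibitor, a lower number a stronger inhibitor:
- compound 1 `O=C1O[C@@H](CO)CN1c1ccc(-n2cc(-c3ccccn3)cn2)c(F)c1` gives 59 ug/mL
- compound 2 `CC(=O)OC[C@H]1CN(c2ccc(-n3cc(-c4ccccn4)cn3)c(F)c2)C(=O)O1` reaches only the limit of the assay, > 400 ug/mL
- compound 3 `COC[C@H]1CN(c2ccc(-n3cc(-c4ccccn4)cn3)c(F)c2)C(=O)O1` reaches only the limit of the assay, > 400 ug/mL

Compound 1 thus stands as the only number shown in this assay; the other two values sit at the limit of > 400 ug/mL in this assay, at which 2 of the 3 values shown sit. Compound 4 `O=CNC[C@H]1CN(c2ccc(-n3cc(-c4ccccn4)cn3)c(F)c2)C(=O)O1` differs from compound 1 by formylamino in place of hydroxy on a saturated chain carbon bound to a saturated ring carbon. For the measured compounds named here, two measured steps bear on this, both replacing the hydrogen of the same hydroxy group: an at least 6.7-fold higher number from compound 1 to compound 2 (0.83 log units; beyond the scatter) and an at least 6.7-fold higher number from compound 1 to compound 3 (0.83 log units; beyond the scatter). Both moved the number up, beyond the scatter. Compound 4 is therefore expected to follow the same direction, with a 5.1-fold higher number from compound 1 to compound 4 (0.71 log units; beyond the scatter). The estimate for compound 4 in this assay is 300 ug/mL, within a range of 120 ug/mL to 500 ug/mL.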

Compound 4, half-maximal inhibitory concentration: > 400 ug/mL
Compound 4 was reported as a limit; the forecaster's own chance of this, stated with the estimate: 55%; middle value at least 1.3-fold (0.12 log units) away from the limit.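

In this assay, replacing the whole hydroxy group, and not only its hydrogen, gives an at least 6.7-fold higher number from compound 1 to compound 4 (0.83 log units; beyond the scatter). Formylamino and hydroxy carry the same count of hydrogen-bond donors and acceptors, so at this saturated chain carbon the rise does not require losing the donor that the acetyl and methyl steps removed. The steps among compound 2, compound 3 and compound 4 cannot be read, as these values are limits: the limit of > 400 ug/mL in this assay, at which 3 of the 4 values shown sit.

On these data alone, whether any group here besides hydroxy gives a readable number remains open. An amine or a carboxylic acid on this chain carbon could show whether the number comes back down toward that of compound 1.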